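The source may report more compounds than this note shows. Statements on the series, on what has been measured and on what is new or still open speak of the compounds shown alone.

Measured in a functional assay on the whole organism for inhibition, with Mus musculus as the target; a higher number here means that more compound is needed for the effect, a lower number that less compound is needed:
- compound 1 `CCCCOC(=O)Nc1cccc2c1CN(C)CC2c1ccccc1`: 4 mg/kg
- compound 2 `CCCCNCC(=O)Nc1cccc2c1CN(C)CC2c1ccccc1`: 32 mg/kg
- compound 3 `CCCCNCCC(=O)Nc1cccc2c1CN(C)CC2c1ccccc1`: about 46 mg/kg

Compound 2 is second of the three numbers, but it cannot be separated from compound 3, as a 1.4-fold higher number from compound 2 to compound 3 (0.16 log units; within the scatter) shows. Both lie clearly above compound 1, with an 8.0-fold higher number from compound 1 to compound 2 (0.90 log units; beyond the scatter) and a 12-fold higher number from compound 1 to compound 3 (1.06 log units; beyond the scatter).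

Compound 4 `CCCCNCC(=O)Nc1cccc2c1CN(C)CC2c1ccc(C)cc1` keeps the side chain of compound 2 and changes the phenyl to 4-methylphenyl: methyl in place of hydrogen on an aromatic carbon. This is methyl in place of hydrogen on an aromatic carbon, para to a large group.

Among the measured compounds shown here, no measured step touches this ring. The two large steps, an 8.0-fold higher number from compound 1 to compound 2 (0.90 log units; beyond the scatter) and a 12-fold higher number from compound 1 to compound 3 (1.06 log units; beyond the scatter), replace butoxy on a carbonyl carbon, and a 1.4-fold higher number from compound 2 to compound 3 (0.16 log units; within the scatter) only alters the chain. For the measured compounds named here, they therefore give no direction for this change, and the data hold no precedent for it. The size of the change alone suggests a small effect in this assay.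

The expected result is no change at the digits printed from compound 2 to compound 4 (within the scatter), which is no step beyond the scatter. For compound 4 the estimated value is 32 mg/kg, with an expected range of 14 mg/kg to 72 mg/kg.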

Compound 4, dose for half-maximal effect: 34 mg/kg
The estimate for compound 4 lay 1.1-fold (0.03 log units) below the measured number, within the range that was stated.
By their numbers in this assay, from the lowest: compound 1; then compounds 2, 4 and 3 (each within the scatter of the next).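

In this assay, the change to 4-methylphenyl gives a 1.1-fold higher number from compound 2 to compound 4 (0.03 log units; within the scatter), so no effect of methyl in place of hydrogen on this aromatic carbon, para to a large group, can be read with the side chain of compound 2. Among the compounds shown here, this is the first measured change on this ring, since the steps among compound 1, compound 2 and compound 3 all lie in the side chain. No measurement available here bears on why the number holds.

A single methyl does not settle the position, and chloro, methoxy or a carboxylic acid on the same carbon could behave differently. As far as these compounds go, it also remains open whether the same methyl would leave the number unchanged with the butoxy carbonyl side chain of compound 1, which stands at 4 mg/kg.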